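The compounds below may be only part of what the source reports. "The series", "measured", "known", "first", "only" and "open" are said of these compounds alone.

Within the data shown here, compound 2 `Cc1ccc(C(=O)CCCN2CCC(C(O)(c3ccccc3)c3ccccc3)CC2)cc1` gives 700 nM in an in vitro assay on Sf9 cells for inhibition of cytochrome P450 2J2 (Homo sapiens) (on this read-out lower numbers stand for stronger inhibition and higher numbers for weaker inhibition), the higher of the two numbers measured so far; its nearest neighbour, compound 1 `C=CCc1ccc(C(=O)CCCN2CCC(C(O)(c3ccccc3)c3ccccc3)CC2)cc1`, gives 400 nM in this assay, and the step between them, a 1.8-fold higher number from compound 1 to compound 2 (0.24 log units; within the scatter), keeps the two within the usual scatter. Compound 3 `O=C(CCCN1CCC(C(O)(c2ccccc2)c2ccccc2)CC1)c1ccc(Br)cc1` differs from compound 2 by bromo in place of methyl on an aromatic carbon. Among the measured compounds shown here, the only measured step that touches this end of the shared core is the one already mentioned, and it exchanged a substituent on a saturated chain carbon rather than on the aromatic carbon itself, so no measured pair shows bromo in place of methyl. What the data do show is that changes at this position have so far moved this assay little. For compound 3 the expected step is therefore a 1.1-fold lower number from compound 2 to compound 3 (0.03 log units; within the scatter), with no direction claimed beyond the scatter. Compound 3 is estimated at 650 nM, within a range from 280 nM to 1500 nM.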

Compound 3, half-maximal inhibitory concentration: 4200 nM
Compound 3: the middle estimate sits 6.5-fold (0.81 log units) below what was measured, and the stated range ends below it.
By their numbers in this assay, from the lowest: compounds 1 and 2 (each within the scatter of the next); then compound 3.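

In this assay, among these compounds, the exchange of methyl for bromo on the aromatic carbon, para to a large group, is the first change at this position to reach beyond the scatter (a 6.0-fold higher number from compound 2 to compound 3 (0.78 log units; beyond the scatter)). Bromo in place of allyl also lies beyond the scatter (an 11-fold higher number from compound 1 to compound 3 (1.02 log units; beyond the scatter)), so this position is not indifferent to its substituent, even though compounds 1 and 2 remain within the scatter of each other. Nothing at hand bears on why bromo differs from these two carbon groups.

The compounds shown leave open whether fluoro, chloro, methoxy or an amine at this position would fall with bromo or with methyl and allyl. They also leave open whether bromo in place of methyl would give a similar step on any other core.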